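From bromo to amino in a weakly cytotoxic series

A few compounds are considered here, and "the series" means these few. Any claim that something is new, unique, unknown or untested is made for them only; others in the source may bear on it.

Of the compounds shown here, three have been read in a functional assay on K562 cells (Homo sapiens) for cytotoxicity, read by MTT assay, with a stated time of 5 days; a higher number here means a weaker inhibitor, a lower number a stronger inhibitor: compound 1 (`COc1ccc(Cn2nncc2-c2cc(OC)c(OC)c(OC)c2)cc1`), compound 2 (`COc1ccc(-c2cnnn2Cc2cc(OC)c(OC)c(OC)c2)cc1[N+](=O)[O-]`) and compound 3 (`COc1ccc(-c2cn(-c3cc(OC)c(OC)c(OC)c3)nn2)cc1Br`). In this assay, for the measured compounds named here, compound 1 gives 8660 nM, the only true number in the set. Compound 2 gives > 10000 nM, which is a limit of the assay and not a number. Compound 3 gives > 10000 nM, again only a limit. Compound 3 therefore sits at the limit of > 10000 nM in this assay, at which 2 of the 3 values shown sit, and no exact starting value exists for it.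

Compound 4 (`COc1ccc(-c2cn(-c3cc(OC)c(OC)c(OC)c3)nn2)cc1N`) differs from compound 3 in one place: amino in place of bromo on an aromatic carbon, with amino in place of bromo on an aromatic carbon, ortho to a methoxy group. Going by the values given here, no measured pair shows a single change of this kind, so the expectation has no direct precedent. A move toward a stronger inhibitor is expected, though with wide uncertainty, and a further limit reading remains quite possible. The estimated change is an at least 2.5-fold lower number from compound 3 to compound 4 (0.39 log units; beyond the scatter). Among the compounds with values here, the only numeric anchor is compound 1 at 8660 nM, so the expected value is placed not far from that level on the stronger side. For compound 4 the estimate is 4000 nM, with an expected range from 300 nM to 10000 nM.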

Compound 4, half-maximal inhibitory concentration: 1300 nM
The estimate for compound 4 lay 3.1-fold (0.49 log units) above the measured number, and the stated range covers the measured number.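

The position ortho to a methoxy group is not indifferent to what it carries: in this assay, amino in place of bromo on an aromatic carbon gives an at least 7.6-fold lower number from compound 3 to compound 4 (0.88 log units; beyond the scatter). For the compounds shown here, this is the first change that can be read at a single place, and it takes the reading off the assay limit and down to a true number for compound 4, which the earlier compounds could not do. The full size of the step remains unknown because compound 3 holds only a limit of the assay and not a number: the limit of > 10000 nM in this assay, at which 2 of the 4 values shown sit.

One pair cannot show whether the gain belongs to the amino group itself or simply to the loss of bromo, nor whether the hydrogen-bond donor that enters with amino plays any part. On these data alone, it also remains open whether a hydroxyl, a methylamino or an acetamide group in the same place would hold or extend the gain, and whether amino would act alike on the core of compound 1.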